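The source may report more compounds than this note shows. Statements on the series, on what has been measured and on what is new or still open speak of the compounds shown alone.

Working notes on the series. The shared core of compound 2 `CN1CCN(C[C@H]2CN(c3ccc(-n4cc(-c5ccccn5)cn4)c(F)c3)C(=O)O2)CC1` carries a 4-methylpiperazin-1-yl group on a saturated chain carbon bound to a saturated ring carbon. In an ADME assay on L02 cells (Homo sapiens) for cytotoxicity, read by MTT assay, with a stated time of 48 h (a lower number here means a stronger inhibitor, a higher number a weaker inhibitor), compound 2 gives 70 ug/mL. Among the measured compounds shown here, of the three values in hand, this is the only one that is a number. Compound 1 `CN(CCC#N)C[C@H]1CN(c2ccc(-n3cc(-c4ccccn4)cn3)c(F)c2)C(=O)O1` is reported only as a limit, > 400 ug/mL. Compound 3 `O=C1O[C@@H](CN2CCCCC2)CN1c1ccc(-n2cc(-c3ccccn3)cn2)c(F)c1` likewise sits at a limit, > 400 ug/mL. The step from compound 1 to compound 2 is an at least 5.7-fold lower number from compound 1 to compound 2 (0.75 log units; beyond the scatter); that from compound 2 to compound 3 is an at least 5.7-fold higher number from compound 2 to compound 3 (0.75 log units; beyond the scatter). Between compound 1 and compound 3 the two limits leave the step unreadable, a step that the two limits leave unreadable from compound 1 to compound 3. Compound 2 thus stands apart with the lowest number shown. Both departures from its 4-methylpiperazin-1-yl return the number to the limit of > 400 ug/mL in this assay, at which 2 of the 3 values shown sit.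

Compound 4 `CCC(=O)NC[C@H]1CN(c2ccc(-n3cc(-c4ccccn4)cn3)c(F)c2)C(=O)O1` is not yet measured. propanoylamino in place of 4-methylpiperazin-1-yl on a saturated chain carbon bound to a saturated ring carbon Both measured departures from the 4-methylpiperazin-1-yl of compound 2, an at least 5.7-fold lower number from compound 1 to compound 2 (0.75 log units; beyond the scatter) and an at least 5.7-fold higher number from compound 2 to compound 3 (0.75 log units; beyond the scatter), were at least modest, so for compound 4 a higher number is expected, most probably again a limit rather than a number. For compound 4 the expected step is a 5.7-fold higher number from compound 2 to compound 4 (0.76 log units; beyond the scatter). Compound 4 is therefore estimated at 400 ug/mL, within 150 ug/mL to 900 ug/mL.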

Compound 4, half-maximal inhibitory concentration: 204 ug/mL
For compound 4 the middle estimate is 2.0-fold (0.29 log units) above the measured one; low and high end bracket the measured number.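

Compound 4 shows that leaving the 4-methylpiperazin-1-yl on this saturated chain carbon need not end at a limit: with propanoylamino in its place, this assay gives a measured number, and the change is a 2.9-fold higher number from compound 2 to compound 4 (0.46 log units; beyond the scatter). The comparisons with the other two departures read an at least 1.9-fold lower number from compound 1 to compound 4 (0.29 log units; that floor lies within the scatter) and an at least 1.9-fold lower number from compound 3 to compound 4 (0.29 log units; that floor lies within the scatter), so neither separates compound 4 from those compounds by more than the usual scatter. A measured number in this assay is therefore not confined to the 4-methylpiperazin-1-yl among the compounds shown, while the (2-cyanoethyl)(methyl)amino and piperidin-1-yl departures remain limits: the limit of > 400 ug/mL in this assay, at which 2 of the 4 values shown sit.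

Open, from the compounds shown here alone, is whether an unsubstituted piperazine or a morpholine ring on the same carbon would fall nearer compound 2, nearer compound 4, or at the limit. Also open, going by these compounds, is how a shorter acetylamino, a longer butanoylamino or a free primary amine would read there, since a single amide cannot show how the number follows the acyl chain.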